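Replacing a Hydrogen with a Nitro Group on the Outer Ring

A few compounds are considered here, and "the series" means these few. Any claim that something is new, unique, unknown or untested is made for them only; others in the source may bear on it.

Measured compounds:
compound 1, `Cc1nc2ccccc2c(=O)n1/N=C/c1ccc(Oc2ccc(Br)cc2)cc1`, 4.64
compound 2, `Cc1nc2ccccc2c(=O)n1/N=C/c1ccc(Oc2ccc(Cl)cc2)cc1`, 4.6
compound 3, `Cc1nc2ccccc2c(=O)n1/N=C/c1ccc(Oc2ccccc2)cc1`, 4.01

These three share one core and differ only in the group at the far end of the phenoxy ring. In a physicochemical assay for lipophilicity, in phosphate buffer, measured as octanol-water partition (on this read-out higher numbers stand for higher lipophilicity and lower numbers for lower lipophilicity), compound 3 sits lowest of the three: a number 0.59 log units lower from compound 2 to compound 3 (beyond the scatter) and a number 0.63 log units lower from compound 1 to compound 3 (beyond the scatter), both beyond the scatter, while a number 0.04 log units lower from compound 1 to compound 2 (within the scatter) lies within it. So the two halogens raise the number by a modest amount, and chloro and bromo cannot be told apart.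

Compound 4, `Cc1nc2ccccc2c(=O)n1/N=C/c1ccc(Oc2ccc([N+](=O)[O-])cc2)cc1`, is not yet measured in this assay. It differs from compound 3 as follows: nitro in place of hydrogen on an aromatic carbon.

Among the compounds with values here, none of the measured steps involves a nitro group; the steps from compound 3 to compound 1 and from compound 3 to compound 2 only show what a halogen does at that place. A nitro group at the same place is expected to leave this assay close to where compound 3 stands, possibly a little lower, so the expected step of a number 0.16 log units lower from compound 3 to compound 4 (within the scatter) is small and may not rise beyond the scatter.

Compound 4 is therefore estimated at 3.85, with a range from 3.45 to 4.25.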

Compound 4, partition coefficient: 4.01
The estimate for compound 4 lay 0.16 log units below the measured number; the measured number falls inside the stated range.
By their numbers in this assay, from the lowest: compounds 3 and 4 (each within the scatter of the next); then compounds 2 and 1 (each within the scatter of the next).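

In this assay, no change at the digits printed from compound 3 to compound 4 (within the scatter), so adding a group of three heavy atoms at this aromatic carbon does not by itself move the number. The halogens had left that possibility open, since both earlier substituents gave higher numbers than hydrogen, whereas a number 0.59 log units lower from compound 2 to compound 4 (beyond the scatter) and a number 0.63 log units lower from compound 1 to compound 4 (beyond the scatter) show that exchanging either halogen for nitro gives a step beyond the scatter. The four compounds therefore form two groups, with chloro and bromo in one and hydrogen and nitro in the other, so the modest rise seen with the halogens is not shared by every group placed here, and nitro is the compound that goes against any rule that a larger group gives a higher number. No measurement given here bears on the reason for this result.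

The compounds shown leave open whether an amine, a carboxylic acid or a longer chain such as butyl at this place would stay with compound 3 or move towards the halogen pair. They also leave open whether a nitro group elsewhere on the same ring would give the same number.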